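The source may hold more compounds than are shown below. What is called first, only, known or untested is meant among the compounds shown, and "the series" means these compounds.

Compounds measured so far:
- compound 1, `COc1ccc(-c2cc(-c3ccc(S(=O)(=O)NC4CC4)cc3)cnc2N)cn1`: 2.7
- compound 2, `COc1ccc(-c2cc(-c3ccc(S(C)(=O)=O)c(F)c3)cnc2N)cn1`: 2.5
- compound 3, `COc1ccc(-c2cc(-c3ccc(S(C)(=O)=O)cc3C(F)(F)F)cnc2N)cn1`: 2.7

All three compounds share the same core and were read in a physicochemical assay for lipophilicity, at pH 7.4; on this read-out lower numbers stand for lower lipophilicity and higher numbers for higher lipophilicity. In this assay compound 1 gives 2.7, and compound 3 gives 2.7, so the two stand level at the digits shown. Compound 2 gives 2.5, a number that sits within the usual scatter of the other two; on these data the three compounds cannot be told apart with confidence.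

The next compound, compound 4, `COc1ccc(-c2cc(-c3ccc(-n4cncn4)cc3)cnc2N)cn1`, has not yet been measured. It differs from compound 1 in one place: 1H-1,2,4-triazol-1-yl in place of cyclopropylsulfamoyl on an aromatic carbon. Among the measured compounds shown here, no pair of measured compounds differs in just this way, so there is no measured step to lean on, and the expectation rests on the ring and atom counts of the exchange alone. A small step toward lower values is expected, a number 0.30 log units lower from compound 1 to compound 4 (within the scatter), which may well stay inside the scatter. Compound 4 is therefore estimated at 2.4, with a likely range from 1.9 to 2.9.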

Compound 4, distribution coefficient: 2.4
Estimate against measurement, compound 4: no gap at the digits printed, and the stated range covers the measured number.
By their numbers in this assay, from the lowest: compounds 4, 2, 1 and 3 (each within the scatter of the next).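

In this assay, this position, on an aromatic carbon para to a large group, accepts a very different substituent: the exchange gives a number 0.30 log units lower from compound 1 to compound 4 (within the scatter) and so leaves the two compounds indistinguishable on this read-out. The change removes the sulfur, the three-membered ring and the only hydrogen-bond donor of cyclopropylsulfamoyl, and brings in a five-membered aromatic ring with 3 hetero atoms, yet no clear shift in the number results. Nothing measured here shows which part of the exchange matters or how the individual features contribute to the number.

Going by these compounds, whether a smaller group such as a primary amine, or an ionisable one such as a carboxylic acid, would also stay within the scatter at this position remains open. So does whether a nitrile would behave like 1H-1,2,4-triazol-1-yl here.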